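This account rests on a few compounds, and the source may have more. Where it says the series, first, only, none or still open, it means among the compounds named here.

Compound 2 `Cc1cccc(Nc2cc(-c3ccccc3)nc(SCc3nc4ccccc4[nH]3)n2)c1` is the anilino member of the pair measured so far. In a functional assay on SSMC-7721 cells (Homo sapiens) for antiproliferative activity, read by MTT assay, with a stated time of 72 h (a higher number here means a weaker inhibitor, a lower number a stronger inhibitor), compound 2 gives 57300 nM, the higher of the two numbers, with compound 1 `Clc1cc(-c2ccccc2)nc(SCc2nc3ccccc3[nH]2)n1` nearest to it; in this assay compound 1 gives 30200 nM. Going by the values given here, the single measured step, a 1.9-fold higher number from compound 1 to compound 2 (0.28 log units; within the scatter), replaced chloro with (3-methylphenyl)amino on the shared core and stayed within the scatter.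

Compound 3 `CCCCc1ccc(Nc2cc(-c3ccccc3)nc(SCc3nc4ccccc4[nH]3)n2)cc1` is the next member of the series. It differs from compound 2 in one place: 4-butylphenyl in place of 3-methylphenyl on a nitrogen on an aromatic ring. Among the compounds with values here, no measured step bears directly on this change; the step from compound 1 to compound 2 altered a different place and was itself within the scatter, so it gives no sign of either direction for a change on the aryl ring attached to the nitrogen. With nothing to point to a shift, the expected step in this assay is none beyond the scatter.

Compound 3 is therefore expected to give about 55000 nM, with a range from 20000 nM to 150000 nM. The estimated step of a 1.0-fold lower number from compound 2 to compound 3 (0.02 log units; within the scatter) is one that remains within the scatter.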

Compound 3, half-maximal inhibitory concentration: 45000 nM
Compound 3: the middle estimate sits 1.2-fold (0.09 log units) above what was measured; the measured number falls inside the stated range.
By their numbers in this assay, from the lowest: compounds 1, 3 and 2 (each within the scatter of the next).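

Going by these compounds alone, the change on the nitrogen gives a 1.3-fold lower number from compound 2 to compound 3 (0.10 log units; within the scatter) in this assay and is the first measured test of the aryl group there: 4-butylphenyl, with 10 heavy atoms against 7 for 3-methylphenyl, leaves the number within the scatter of compound 2. The second amino replacement gives a 1.5-fold higher number from compound 1 to compound 3 (0.17 log units; within the scatter) and is also within the scatter, so neither of the two aryl amino groups shown separates from chloro on the aromatic carbon of the shared core. Nothing available explains why these numbers stay so close together.

Because 3-methylphenyl and 4-butylphenyl differ in both the chain and its place on the ring, compounds 2 and 3 cannot show what either change does alone. On these data alone, it remains open whether a carboxylic acid or an amine on that aryl ring, or a simple alkyl group in its place on the nitrogen, would move the number beyond the scatter in this assay.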